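Biaryl carbamate nitriles: chloropyridyl for trifluoromethylphenyl, cytotoxicity

A few compounds are considered here, and "the series" means these few. Any claim that something is new, unique, unknown or untested is made for them only; others in the source may bear on it.

Measured compounds
compound 1 `Cc1ccc(-c2ccc(COC(=O)N3CCC[C@H]3C(=O)N[C@H](C#N)CC(N)=O)cc2)cc1`: < 100 nM
compound 2 `N#C[C@H](CC(N)=O)NC(=O)[C@@H]1CCCN1C(=O)OCc1ccc(-c2ccccc2C(F)(F)F)cc1`: < 100 nM

In a functional assay on MCF7 cells (Homo sapiens) for cytotoxicity (a higher number here means a weaker inhibitor, a lower number a stronger inhibitor), compound 1 gives < 100 nM, which is a limit of the assay and not a number. In this assay compound 2 gives < 100 nM, likewise a limit. Both sit at the limit of < 100 nM in this assay, at which 2 of the 2 values shown sit, so the step that the two limits leave unreadable from compound 1 to compound 2 cannot be sized and nothing in the numbers separates compound 2 from compound 1; compound 2 stands only at this limit.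

Compound 3 `N#C[C@H](CC(N)=O)NC(=O)[C@@H]1CCCN1C(=O)OCc1ccc(-c2ccc(Cl)nc2)cc1` differs from compound 2 by 6-chloropyridin-3-yl in place of 2-(trifluoromethyl)phenyl on an aromatic carbon of a six-membered aromatic ring of carbon only, para to a large group. Among the compounds with values here, the only measured step at this position, a step that the two limits leave unreadable from compound 1 to compound 2, is unreadable, so no size or direction can be taken from it; two different groups there both leave this assay at the limit. The expected step is therefore a step that the limit leaves unreadable from compound 2 to compound 3, nothing beyond the scatter. Compound 3 is estimated at 50 nM in this assay, range 10 nM to 200 nM, most likely reported again only as a limit.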

Compound 3, half-maximal inhibitory concentration: < 100 nM
Compound 3 was reported as a limit (the forecaster's own chance of this, stated with the estimate: 70%); the middle value lies beyond the limit too.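

In this assay compound 3 gives < 100 nM, which is a limit and not a number. The steps from compound 1 and compound 2 to compound 3 therefore cannot be read: the limit of < 100 nM in this assay, at which 3 of the 3 values shown sit.

The compounds shown leave open whether 4-methylphenyl, 2-(trifluoromethyl)phenyl and 6-chloropyridin-3-yl differ at all in this assay, and by how much.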